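The source may hold more compounds than are shown below. What is called first, only, known or untested is meant among the compounds shown, and "the series" means these compounds.

In an ADME assay on HEK-293T cells (Homo sapiens) for cytotoxicity, read by CCK-8 assay, with a stated time of 48 h (a higher number here means a weaker inhibitor, a lower number a stronger inhibitor), compound 3, `O=S(=O)(NCCNC(=S)Nc1ccc(Cl)cc1)c1ccc(-c2ccccc2OCc2ccccc2)s1`, gives 12100 nM. That is the highest of the two numbers measured here. Among the compounds with values here, its nearest neighbour is compound 2, `O=S(=O)(NCCNC(=S)Nc1cccc(Cl)c1)c1ccc(-c2ccccc2OCc2ccccc2)s1`, which gives 10200 nM; the step of a 1.2-fold higher number from compound 2 to compound 3 (0.07 log units; within the scatter) is the only change measured between two plain numbers. Compound 1, `O=C(Nc1cccc([N+](=O)[O-])c1)N1CCN(S(=O)(=O)c2sccc2-c2ccccc2Oc2ccc(O)c(O)c2)CC1`, is recorded only as a limit, > 20000 nM, so no number is known for it; this is the limit described by the limit of > 20000 nM in this assay, at which 1 of the 3 values shown sits.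

Compound 4, `Cc1cc(C)cc(NC(=O)NCCNS(=O)(=O)c2ccc(-c3ccccc3OCc3ccccc3)s2)c1`, has not yet been measured. Compared with compound 3 the change is a group of 11 heavy atoms (9 carbon, 1 nitrogen, 1 oxygen; one six-membered aromatic ring of carbon only) in place of a group of 10 heavy atoms (7 carbon, 1 nitrogen, 1 sulfur, 1 chlorine; one six-membered aromatic ring of carbon only), on an amine nitrogen. The change swaps the sulfur-bearing thiourea group for a carbamoyl group and replaces the chlorine by two methyl groups on the aromatic ring, so it is larger than the change from compound 2 to compound 3, which moved the chlorine from the 3-position to the 4-position and stayed within the scatter. Within the data shown here, no measured step covers a swap of this kind, so the only guide is that the one measured change left the number essentially unmoved. On that basis compound 4 is expected to sit close to compound 3, with the step of a 1.0-fold lower number from compound 3 to compound 4 (0.00 log units; within the scatter) expected to stay within the scatter, and its estimated value is 12000 nM, most likely between 5000 nM and 30000 nM.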

Compound 4, half-maximal inhibitory concentration: > 20000 nM
Compound 4 ended at the assay's limit; the forecaster's own chance of this, stated with the estimate: 30%; at least 1.6-fold (0.22 log units) between middle value and limit.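

In this assay, placing (3,5-dimethylphenyl)carbamoyl on the amine nitrogen, in place of the chlorophenyl thiourea end, gives an at least 1.6-fold higher number from compound 3 to compound 4 (0.21 log units; that floor lies within the scatter) and an at least 1.9-fold higher number from compound 2 to compound 4 (0.29 log units; that floor lies within the scatter). Both steps are floors, so the true gaps could be larger, but neither floor on its own places compound 4 beyond the scatter from the two chlorine-bearing compounds. Unlike the chlorine shift from one ring position to another, this larger change at the same end of the molecule gives no number at all, only a limit of the assay, and it brings the limit into the series that shares this core: the limit of > 20000 nM in this assay, at which 2 of the 4 values shown sit.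

The change alters two things at once, the sulfur of the thiourea and the ring substituents, so the compounds shown cannot say which of the two matters, and a chlorophenyl urea or a 3,5-dimethylphenyl thiourea would separate them. As far as these compounds go, how this end of the molecule behaves with an amine or a carboxylic acid on the aromatic ring, or with a longer chain leading to it, also remains open.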